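Branched chain swap in the acetylphenyl amide series

The compounds below may be only part of what the source reports. "The series", "measured", "known", "first", "only" and "open" are said of these compounds alone.

Compound 1 `CC(=O)c1ccc(NC(=O)C(CC(C)C)N(C(=O)c2ccccc2)S(=O)(=O)c2ccc(C)cc2)cc1` gives 67.3% in a functional assay for inhibition, read by spectrophotometry, with a stated time of 20 min, tested at 4 mg/mL; on this read-out lower numbers stand for a weaker effect and higher numbers for a stronger effect at the one concentration tested. Compound 2 `CCC(C)C(C(=O)Nc1ccc(C(C)=O)cc1)N(C(=O)c1ccccc1)S(=O)(=O)c1ccc(C)cc1` carries the change (sec-butyl in place of isobutyl on a saturated chain carbon bound to an amide-type nitrogen and a carbonyl carbon); in this assay compound 2 gives 41.1%, and the step is a number 26.2 percentage points lower from compound 1 to compound 2 (beyond the scatter). Compound 3 `CC(=O)c1ccc(NC(=O)C(CC(C)C)N(C(=O)c2ccccc2)S(=O)(=O)c2ccccc2)cc1` differs from compound 1 by hydrogen in place of methyl on an aromatic carbon; in this assay compound 3 gives 46.9%, a step of a number 20.4 percentage points lower from compound 1 to compound 3 (beyond the scatter). The values of compound 2 and compound 3 lie within the scatter of each other, so no order between them is drawn, and compound 1 stands beyond the scatter of both.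

Compound 4 `CCC(C)C(C(=O)Nc1ccc(C(C)=O)cc1)N(C(=O)c1ccccc1)S(=O)(=O)c1ccccc1` has not yet been measured in this assay. It differs from compound 3 by sec-butyl in place of isobutyl on a saturated chain carbon bound to an amide-type nitrogen and a carbonyl carbon, the same change that was made from compound 1 to compound 2, now on the core of compound 3, whose difference from the core of compound 1 is the one counted already (methyl to hydrogen on the aromatic carbon). The place of the change is worded identically in both pairs.

The step from compound 3 to compound 4 is expected to be a number 22.9 percentage points lower from compound 3 to compound 4 (beyond the scatter), a modest lowering of a size similar to the earlier step, because the same change gave a number 26.2 percentage points lower from compound 1 to compound 2 (beyond the scatter) and because compound 3 starts from 46.9%. Among the measured compounds shown here, with only one prior instance of this change, the expected step is taken as somewhat smaller than the earlier one, since the lower starting value leaves less room. Compound 4 is expected to give 24% in this assay, with a range from 8% to 40%.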

Compound 4, a percentage reported as inhibition, at one concentration (the size of the read-out at that concentration, not a potency): 15.5%
Compound 4: middle estimate off by 8.5 percentage points, on the high side, within the range that was stated.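

On the core of compound 3, sec-butyl in place of isobutyl gives a number 31.4 percentage points lower from compound 3 to compound 4 (beyond the scatter), and in this assay this agrees within the scatter with the step seen on the core of compound 1: the same change on two cores in this assay, a number 26.2 percentage points lower (beyond the scatter) from compound 1 to compound 2 and a number 31.4 percentage points lower (beyond the scatter) from compound 3 to compound 4, 5.2 percentage points apart, within the scatter of two such steps. Read the other way round, hydrogen in place of methyl on an aromatic carbon gives a number 25.6 percentage points lower from compound 2 to compound 4 (beyond the scatter) on the sec-butyl core, which agrees in the same way with the step on the isobutyl core: the same change on two cores in this assay, a number 20.4 percentage points lower (beyond the scatter) from compound 1 to compound 3 and a number 25.6 percentage points lower (beyond the scatter) from compound 2 to compound 4, 5.2 percentage points apart, within the scatter of two such steps. Across these four compounds the two changes therefore carry from one core to the other with no compound going against it, but the two comparisons come from the same four values and so count as one observation, which shows neither a potency nor a rule for any other core.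

Still open, from the compounds shown here alone, is whether the step from isobutyl holds for a longer chain or a benzyl group on the same saturated chain carbon, and whether the aromatic methyl step holds for methoxy or chlorine on that aromatic carbon. Also open, going by these compounds, is whether either step survives when the acetyl group gives way to a carboxylic acid or an amine.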